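This account rests on a few compounds, and the source may have more. Where it says the series, first, only, none or still open, it means among the compounds named here.

Measured compounds:
compound 1, `CCc1cc(C)c(C(=O)N=C(N)N)cc1S(C)(=O)=O`, 4.8 nM
compound 2, `CCCSc1cc(C)c(C(=O)N=C(N)N)cc1S(C)(=O)=O`, 6.8 nM
compound 3, `Cc1cc(Nc2cccc(Cl)c2)c(S(C)(=O)=O)cc1C(=O)N=C(N)N`, 33 nM

In a functional assay for inhibition of sodium/hydrogen exchanger (Oryctolagus cuniculus) (a higher number here means a weaker inhibitor, a lower number a stronger inhibitor), compound 3 stands at the highest number of the three, the weakest inhibitor of the set. Compound 1 and compound 2 give values within the scatter of each other, a 1.4-fold higher number from compound 1 to compound 2 (0.15 log units; within the scatter). Replacing either small group with the (3-chlorophenyl)amino group raised the number beyond the scatter: a 6.9-fold higher number from compound 1 to compound 3 (0.84 log units; beyond the scatter) and a 4.9-fold higher number from compound 2 to compound 3 (0.69 log units; beyond the scatter).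

Compound 4, `Cc1cc(C#N)c(S(C)(=O)=O)cc1C(=O)N=C(N)N`, is not yet measured. It differs from compound 3 in one place: cyano in place of (3-chlorophenyl)amino on an aromatic carbon.

Within the data shown here, the steps that bear on this change are those leading into compound 3 from compound 1 and compound 2, both of which show that a small substituent at this position gives a lower number than the (3-chlorophenyl)amino group. Cyano is again a small group, but no measured compound carries a cyano here, so the comparison is indirect. The expectation is a modest fall in this assay back toward the values of compound 1 and compound 2, though with wide uncertainty, the estimated step being a 2.8-fold lower number from compound 3 to compound 4 (0.44 log units; beyond the scatter). Compound 4 is estimated at 12 nM, in the range 4 nM to 40 nM.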

Compound 4, half-maximal inhibitory concentration: 70 nM
Compound 4: the middle estimate sits 5.8-fold (0.77 log units) below what was measured; measured number above the stated range.
By their numbers in this assay, from the lowest: compounds 1 and 2 (each within the scatter of the next); then compound 3; then compound 4.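

In this assay, a group with few heavy atoms on this aromatic carbon, ortho to a methylsulfonyl group, does not by itself give a low number: cyano, with 2 heavy atoms, replaces the (3-chlorophenyl)amino group, with 8 heavy atoms, and the result is a 2.1-fold higher number from compound 3 to compound 4 (0.33 log units; beyond the scatter) rather than a fall. The ethyl and propylsulfanyl groups therefore stand apart from cyano, with a 10-fold higher number from compound 2 to compound 4 (1.01 log units; beyond the scatter) and a 15-fold higher number from compound 1 to compound 4 (1.16 log units; beyond the scatter) in this series, so the low numbers of those two compounds cannot be read as a general result for any compact group at this place. The data at hand offer nothing that accounts for this order.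

The compounds shown leave open whether an amino group, a methoxy group or a single chlorine atom at this place would sit with compound 1 and compound 2 or with compound 4. They also leave open whether an unsubstituted phenylamino group or a longer alkyl chain would shift the number in this assay, and so how much of the value of compound 3 belongs to its chlorine atom.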